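This account rests on a few compounds, and the source may have more. Where it says the series, first, only, none or still open, it means among the compounds named here.

Measured in an assay on isolated protein for activation of cGMP-dependent protein kinase 1 (Homo sapiens), read by ADP-Glo, with stated times of 120 min and 40 min; a higher number here means that more compound is needed for the effect, a lower number that less compound is needed:
Compound 1 `Cn1cc(CN2CCC[C@H](OCc3cc(Cl)cc(Cl)c3)[C@@H]2c2ccccc2)cn1` gives 110000 nM.
Compound 2 `O=C(O)c1cncc(CN2CCC[C@H](OCc3cc(Cl)cc(Cl)c3)[C@@H]2c2ccccc2)c1` gives 117000 nM.
Compound 3 `Clc1cc(Cl)cc(CO[C@H]2CCCN(Cc3nccs3)[C@H]2c2ccccc2)c1` reaches only the limit of the assay, > 200000 nM, and so has no number.

Compound 1 stands lowest of the two numbers, with compound 2 nearest to it; the gap between them is within the scatter. Compound 3 sits at the limit (the limit of > 200000 nM in this assay, at which 1 of the 3 values shown sits).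

Compound 4 `O=C(O)c1ccc(CN2CCC[C@H](OCc3cc(Cl)cc(Cl)c3)[C@@H]2c2ccccc2)cn1` has not been measured. It differs from compound 1 in one place: 6-carboxypyridin-3-yl in place of 1-methyl-1H-pyrazol-4-yl on a saturated chain carbon bound to an amine nitrogen in a ring. For the measured compounds named here, two measured steps bear on this. The closest is the change from compound 1 to compound 2, where a carboxypyridinyl group also replaces the pyrazolyl group; it gave a 1.1-fold higher number from compound 1 to compound 2 (0.03 log units; within the scatter). The change to a thiazolyl group gave an at least 1.8-fold higher number from compound 1 to compound 3 (0.25 log units; that floor lies within the scatter), a floor that also lies within the scatter. Every replacement of the pyrazolyl group seen so far has therefore left this assay unchanged, and the same is expected here: compound 4 is estimated to give 115000 nM, between 60000 nM and 220000 nM, meaning an expected step of a 1.0-fold higher number from compound 1 to compound 4 (0.02 log units; within the scatter).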

Compound 4, half-maximal effective concentration: > 200000 nM
Compound 4: a limit, no number; the forecaster's own chance of this, stated with the estimate: 25%; middle value at least 1.7-fold (0.24 log units) from the limit.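

In this assay compound 4 ends at a limit and not at a number, as compound 3 does: the limit of > 200000 nM in this assay, at which 2 of the 4 values shown sit. Measured against the earlier groups at this place, the change gives an at least 1.8-fold higher number from compound 1 to compound 4 (0.25 log units; that floor lies within the scatter), and an at least 1.7-fold higher number from compound 2 to compound 4 (0.23 log units; that floor lies within the scatter). So 5-carboxypyridin-3-yl gives a number and 6-carboxypyridin-3-yl does not, which means that the two carboxypyridinyl groups need not behave alike here, although these floors alone do not establish a real difference between them.

The step from compound 3 to compound 4 cannot be read, as both values are limits. As far as these compounds go, it also remains open what number compound 4 would give, and whether an amine or an amide in place of the carboxylic acid would lower the number in this assay's read-out.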